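From 4-Methylphenyl to Azepan-1-yl on the Shared Core

This account rests on a few compounds, and the source may have more. Where it says the series, first, only, none or still open, it means among the compounds named here.

In a functional assay on DLD-1 cells (Homo sapiens) for antiproliferative activity, read by CellTiter-Glo, with a stated time of 72 h (a lower number here means a stronger inhibitor, a higher number a weaker inhibitor), compound 3 `Cc1ccc(C2CCN(S(=O)(=O)c3c(C)cc(C)cc3C)CC2)cc1` gives 2200 nM, the higher of the two exact numbers available. Compound 1 `Cc1cc(C)c(S(=O)(=O)N2CCC(N3CCC(CCO)CC3)CC2)c(C)c1` gives 19 nM, and the gap is large: a 120-fold higher number from compound 1 to compound 3 (2.06 log units; beyond the scatter). Compound 2 `Cc1cc(C)c(S(=O)(=O)N2CCC(c3ccccc3)CC2)c(C)c1` is recorded only as a limit, > 5000 nM.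

The unmeasured compound 4 `Cc1cc(C)c(S(=O)(=O)N2CCC(N3CCCCCC3)CC2)c(C)c1` carries azepan-1-yl in place of 4-methylphenyl on a saturated ring carbon. Two large measured steps bear on this change. Both replace the 4-(2-hydroxyethyl)piperidin-1-yl of compound 1, one with 4-methylphenyl, as already shown, and the other with phenyl: an at least 260-fold higher number from compound 1 to compound 2 (2.42 log units; beyond the scatter). The methyl difference matters far less, at an at least 2.2-fold lower number from compound 2 to compound 3 (0.35 log units; beyond the scatter). Azepan-1-yl resembles the group in compound 1 in being a non-aromatic ring with a hetero atom, but it has no 2-hydroxyethyl chain, and no measured compound isolates what that chain contributes. A large move toward compound 1 is therefore expected, though probably not the whole distance. The expected change in this assay is a lower number, estimated as an 18-fold lower number from compound 3 to compound 4 (1.26 log units; beyond the scatter). For compound 4, the estimated value is 120 nM, with an expected range of 20 nM to 900 nM.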

Compound 4, half-maximal inhibitory concentration: 5.3 nM
The estimate for compound 4 lay 23-fold (1.35 log units) above the measured number, outside the stated range (below it).
By their numbers in this assay, from the lowest: compound 4; then compound 1; then compound 3. At a limit, above all of these: compound 2.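

The result shows that a 2-hydroxyethyl chain is not required for a low number in this assay at this saturated ring carbon: azepan-1-yl, which has no such chain, gives a 3.6-fold lower number from compound 1 to compound 4 (0.55 log units; beyond the scatter). The same group in place of 4-methylphenyl gives a 420-fold lower number from compound 3 to compound 4 (2.62 log units; beyond the scatter), and since both groups hold the same number of heavy atoms, that count alone does not separate them; they differ in that the entering group is a seven-membered non-aromatic ring with a nitrogen, while the leaving group is an aromatic ring of carbon only. In place of phenyl the change gives an at least 940-fold lower number from compound 2 to compound 4 (2.97 log units; beyond the scatter), a step with an open end, as the number for compound 2 is only a limit: the limit of > 5000 nM in this assay, at which 1 of the 4 values shown sits.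

Going by these compounds, it remains open whether the ring nitrogen or the ring size carries this gain, and a cycloheptyl group or an unsubstituted piperidin-1-yl at this place would separate the two. Also open, on these data alone, is what a 2-hydroxyethyl chain would do on the azepan-1-yl ring itself.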